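The source may report more compounds than this note shows. Statements on the series, on what has been measured and on what is new or still open speak of the compounds shown alone.

Of the compounds shown here, three sharing one core have been tested in an ADME assay on cells (Hepatocyte, Homo sapiens) for metabolic stability; a higher number here means that the compound lasts longer, a lower number that the compound disappears faster. Compound 1 `CS(=O)(=O)NC1CCC(CN2CCN(c3cc(=O)c4cc(C(F)(F)F)cc([N+](=O)[O-])c4s3)CC2)CC1` carries a methanesulfonamido group on a saturated ring carbon; in this assay compound 1 gives > 1.55 h, which is a limit of the assay rather than a number. Compound 2 `O=C(OC1CCC(CN2CCN(c3cc(=O)c4cc(C(F)(F)F)cc([N+](=O)[O-])c4s3)CC2)CC1)c1cccs1` gives 0.0917 h, and compound 3 `Cc1ccc(C(=O)OC2CCC(CN3CCN(c4cc(=O)c5cc(C(F)(F)F)cc([N+](=O)[O-])c5s4)CC3)CC2)cc1` gives 0.148 h. Of the two numbers compound 2 is the lowest, and the nearest step is a 1.6-fold higher number from compound 2 to compound 3 (0.21 log units; within the scatter). The esters sit far below compound 1: an at least 16-fold lower number from compound 1 to compound 2 (1.22 log units; beyond the scatter) and an at least 10-fold lower number from compound 1 to compound 3 (1.02 log units; beyond the scatter).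

Going by the values given here, compound 4 `CC(=O)OC1CCC(CN2CCN(c3cc(=O)c4cc(C(F)(F)F)cc([N+](=O)[O-])c4s3)CC2)CC1` is not yet measured. methyl in place of thiophen-2-yl on a carbonyl carbon The one measured change on the carbonyl carbon is a 1.6-fold higher number from compound 2 to compound 3 (0.21 log units; within the scatter). Accordingly the expected step is a 1.3-fold higher number from compound 2 to compound 4 (0.12 log units; within the scatter), nothing beyond the scatter. Compound 4 is therefore estimated at 0.12 h, between 0.05 h and 0.35 h.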

Compound 4, half-life: < 0.15 h
Compound 4 was reported as a limit; the forecaster's own chance of this, stated with the estimate: 5%; the middle value is on the limit's open side.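

In this assay compound 4 gives < 0.15 h, which is a limit and not a number. Even with only a methyl on the carbonyl carbon, and no aromatic ring there, the ester stays far under the methanesulfonamido compound, with an at least 10-fold lower number from compound 1 to compound 4 (1.01 log units; beyond the scatter). On these data alone, the steps from compound 2 and compound 3 to compound 4 cannot be read, so the order of these three esters stays unknown.

Still open, as far as these compounds go, is whether the low numbers go with the ester link itself. An amide or an ether on that saturated ring carbon would test this.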